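A Tetrazolyl Amide Series: Chloro Replaced by Methoxy

A few compounds are considered here, and "the series" means these few. Any claim that something is new, unique, unknown or untested is made for them only; others in the source may bear on it.

Measured so far:
- compound 1, `CCCCOc1cccc(C(=O)Nc2nn[nH]n2)n1`: 8%
- compound 2, `O=C(Nc1nn[nH]n1)c1ncccc1Cl`: 22%

Both compounds were tested in a functional assay on the whole organism for inhibition, with Rattus norvegicus as the target, at a dose of 10 mg/kg by the oral route; on this read-out higher numbers stand for a stronger effect at the one dose given and lower numbers for a weaker effect. Of the two, compound 2 gives the higher number, and its gap to compound 1 lies beyond the usual scatter of repeated runs, so compound 2 stands clearly ahead on the numbers shown.

Compound 3, `COc1cccnc1C(=O)Nc1nn[nH]n1`, is not yet measured. It differs from compound 2 in one place: methoxy in place of chloro on an aromatic carbon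

Among the compounds with values here, no pair of measured compounds shares a single change of this kind, so there is no measured step to lean on. Given that compound 2 gives 22% in this assay and the change is small in size, the step of a number 6 percentage points lower from compound 2 to compound 3 (within the scatter) is expected to stay within or only slightly beyond the scatter, with the direction uncertain. Compound 3 is estimated at 16%, in the range 0% to 34%.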

Compound 3, a percentage reported as inhibition, in the whole organism at one dose (the size of the read-out at that dose, not a potency): 0%
Compound 3: middle estimate off by 16 percentage points, on the high side; measured number inside the range.
By their numbers in this assay, from the lowest: compounds 3 and 1 (each within the scatter of the next); then compound 2.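

In this assay, within the data shown here, putting methoxy in place of chloro on this aromatic carbon, ortho to a group of 8 heavy atoms and two atoms from the ring nitrogen, gives a number 22 percentage points lower from compound 2 to compound 3 (beyond the scatter) in the only single-place change measured so far. The result shows that the read-out at this position can respond to a small replacement, in which one chlorine leaves and a carbon and an oxygen enter, bringing one hydrogen-bond acceptor. No measurement at hand bears on the reason for this drop.

Going by these compounds, whether the drop is specific to methoxy or would follow other replacements of chloro remains open. An amine, a fluorine or a longer chain such as ethoxy on the same carbon would help to separate these possibilities.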